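Methoxy added to the benzoyl of compound 3

This account rests on a few compounds, and the source may have more. Where it says the series, first, only, none or still open, it means among the compounds named here.

Three compounds have numbers in an assay on HEK293 cells for displacement of a labelled ligand from prostaglandin D2 receptor 2 (Homo sapiens), read by scintillation counting, with a stated time of 2 h; on this read-out lower numbers stand for stronger inhibition and higher numbers for weaker inhibition. Compound 1 `O=C(O)COc1cccc(CCCn2cc(C(c3ccc(F)cc3)c3ccc(F)cc3)ccc2=O)c1` gives 11 nM, compound 2 `O=C(O)COc1cccc(CCCn2cc(C(c3ccc(Cl)cc3)c3ccc(Cl)cc3)ccc2=O)c1` gives 9.2 nM, and compound 3 `O=C(O)COc1cccc(CCCN(CCC(c2ccccc2)c2ccccc2)C(=O)c2ccccc2)c1` gives 9.7 nM. Compound 3 stands second highest of the three, but its gap to compound 2 and its gap to compound 1 both lie within the scatter, so none of the three is separated from the others. Compound 4 `COc1ccc(C(=O)N(CCCc2cccc(OCC(=O)O)c2)CCC(c2ccccc2)c2ccccc2)cc1` differs from compound 3 by methoxy in place of hydrogen on an aromatic carbon, a methoxy in place of hydrogen on an aromatic carbon, para to a large group. For the measured compounds named here, no step of this kind is known among the measured compounds, so the expected step of a 1.0-fold higher number from compound 3 to compound 4 (0.01 log units; within the scatter) in this assay is none beyond the scatter. Compound 4 is therefore estimated at 10 nM, with a range from 4 nM to 25 nM.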

Compound 4, half-maximal inhibitory concentration: 5.5 nM
Estimate against measurement, compound 4: 1.8-fold (0.26 log units) above; low and high end bracket the measured number.
By their numbers in this assay, from the lowest: compounds 4, 2, 3 and 1 (each within the scatter of the next).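

For the compounds shown here, this is the first one-place step: with methoxy in place of hydrogen on an aromatic carbon, para to a large group, a 1.8-fold lower number from compound 3 to compound 4 (0.25 log units; within the scatter) in this assay is read. The benzoyl of compound 3 therefore accepts 4-methoxy at this carbon with no change beyond the scatter. No measurement offered here bears on the size of this step.

Open, going by these compounds, is how a hydroxyl, a chlorine or an amine would read at this carbon. Also open, on these data alone, is whether a longer chain such as ethoxy would read like methoxy.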